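The source may report more compounds than this note shows. Statements on the series, on what has been measured and on what is new or still open speak of the compounds shown alone.

Compound 2 `Cc1nc2ccc(COc3ccc4c(c3)c(SC(C)(C)C)c(CC(C)(C)C(=O)O)n4Cc3ccc(Cl)cc3)cc2s1` is one of three compounds that have been tested in a functional assay (blood) for inhibition, with Homo sapiens as the target; on this read-out lower numbers stand for stronger inhibition and higher numbers for weaker inhibition. In this assay compound 2 gives > 3000 nM, which is a limit of the assay rather than a number. Compound 1 `CC(C)(C)Sc1c(CC(C)(C)C(=O)O)n(Cc2ccc(Cl)cc2)c2ccc(OCc3nc4cc(C(F)(F)F)ccc4s3)cc12` gives > 3000 nM, also a limit. Compound 3 `CC(C)(C)Sc1c(CC(C)(C)C(=O)O)n(Cc2ccc(Cl)cc2)c2ccc(OCc3ccncc3)cc12` gives > 3000 nM, again a limit. For the measured compounds named here, because of the limit of > 3000 nM in this assay, at which 3 of the 3 values shown sit, none of the three compounds has a readable value, and the one measured change in this place, a step that the two limits leave unreadable from compound 2 to compound 3, cannot be sized either.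

Compound 4 `CC(C)(C)Sc1c(CC(C)(C)C(=O)O)n(Cc2ccc(Cl)cc2)c2ccc(OCc3cccs3)cc12` has not yet been measured. It differs from compound 2 in one place: thiophen-2-yl in place of 2-methyl-1,3-benzothiazol-6-yl on a saturated chain carbon bound to an oxygen on an aromatic ring. Going by the values given here, the only measured step that bears on a change at this position is the step from compound 2 to compound 3, and its size is unreadable, since both of its ends sit at the limit. Among the compounds with values here, the three limits together show only that no compound so far reaches a measurable inhibition in this assay, so no direction or size of step beyond the scatter can be expected from them.

For compound 4 the estimated value is 5000 nM, with a range from 2000 nM to 20000 nM, meaning an expected step that the limit leaves unreadable from compound 2 to compound 4. It is expected that the assay will most likely again report only a limit for compound 4.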

Compound 4, half-maximal inhibitory concentration: > 3000 nM
Compound 4 ended at the assay's limit (the forecaster's own chance of this, stated with the estimate: 75%); the middle value lies beyond the limit too.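

In this assay compound 4 gives > 3000 nM, which is a limit of the assay. The steps to compound 4 from compound 2 and from compound 3 therefore cannot be read: the limit of > 3000 nM in this assay, at which 4 of the 4 values shown sit.

The compounds shown leave open whether thiophen-2-yl, pyridin-4-yl and 2-methyl-1,3-benzothiazol-6-yl differ at all in their effect on inhibition.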